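The source may report more compounds than this note shows. Statements on the series, on what has been measured and on what is new or still open speak of the compounds shown alone.

Measured so far in an assay on isolated protein for inhibition of tyrosine-protein kinase receptor UFO (Homo sapiens), read by FRET and Z'-LYTE, with a stated time of 1.5 h; a lower number here means a stronger inhibitor, a higher number a weaker inhibitor:
compound 1 `Cc1c(C(=O)Nc2ccc(Oc3ncnc4[nH]cc(-c5ccccc5)c34)c(F)c2)c(=O)c2cc(Cl)ccc2n1C`: 1890 nM
compound 2 `C=C(C)c1ccc2c(c1)c(=O)c(C(=O)Nc1ccc(Oc3ncnc4[nH]cc(-c5ccccc5)c34)c(F)c1)c(C)n2C`: 170 nM
compound 3 `Cc1c(C(=O)Nc2ccc(Oc3ncnc4[nH]cc(-c5ccccc5)c34)c(F)c2)c(=O)c2cc(C3CCCC3)ccc2n1C`: 200 nM

Within this set compound 3 sits with compound 2, the step of a 1.2-fold higher number from compound 2 to compound 3 (0.07 log units; within the scatter) lying within the scatter, while the step of a 9.5-fold lower number from compound 1 to compound 3 (0.98 log units; beyond the scatter) separates it clearly from compound 1. Compound 4 `Cc1c(C(=O)Nc2ccc(Oc3ncnc4[nH]cc(-c5ccccc5)c34)c(F)c2)c(=O)c2cc(-c3ccccc3)ccc2n1C` follows from compound 3 by a single change: phenyl in place of cyclopentyl on an aromatic carbon. For the measured compounds named here, the steps that bear on it are those at the same aromatic carbon. From compound 1 the replacement of chloro gave an 11-fold lower number from compound 1 to compound 2 (1.05 log units; beyond the scatter) and a 9.5-fold lower number from compound 1 to compound 3 (0.98 log units; beyond the scatter), two different carbon groups landing close together, and the exchange between those two groups, a 1.2-fold higher number from compound 2 to compound 3 (0.07 log units; within the scatter), stayed within the scatter. A further carbon-only group of similar count at this carbon is therefore expected to give at most a small step in this assay, with no clear direction, so the estimate for compound 4 is 200 nM (range 80 nM to 500 nM), corresponding to an expected step of no change at the digits printed from compound 3 to compound 4 (within the scatter).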

Compound 4, half-maximal inhibitory concentration: > 10000 nM
Compound 4 was reported as a limit; the forecaster's own chance of this, stated with the estimate: 2%; middle value at least 50-fold (1.69 log units) from the limit.
By their numbers in this assay, from the lowest: compounds 2 and 3 (each within the scatter of the next); then compound 1. At a limit, above all of these: compound 4.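

In this assay compound 4 is reported only as a limit: the limit of > 10000 nM in this assay, at which 1 of the 4 values shown sits.

For the compounds shown here, this position does distinguish among carbon-only groups, which the earlier compounds did not show: phenyl in place of cyclopentyl gives an at least 50-fold higher number from compound 3 to compound 4 (1.69 log units; beyond the scatter), and phenyl in place of 1-methylethenyl gives an at least 58-fold higher number from compound 2 to compound 4 (1.76 log units; beyond the scatter), although those two groups lay within the scatter of each other. Phenyl also compares unfavourably with chloro, with an at least 5.2-fold higher number from compound 1 to compound 4 (0.72 log units; beyond the scatter), so replacing chloro with a carbon group does not in itself lower the number.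

The compounds shown leave open whether the loss follows from the aromatic ring or from the ring of six carbons, and cyclohexyl at this carbon would separate the two. On these data alone, whether a pyridyl ring or a phenyl ring bearing an amine behaves like phenyl also remains open.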